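This account rests on a few compounds, and the source may have more. Where it says the series, first, only, none or still open, it means among the compounds named here.

Of the compounds shown here, three have so far been tested in an ADME assay on BEAS-2B cells (Homo sapiens) for inhibition, read by MTT assay, with a stated time of 24 h; a lower number here means a stronger inhibitor, a higher number a weaker inhibitor: compound 1 `COc1ccc(NC(=O)Cn2c(=O)c(/C=C\c3ccncc3)nc3ccccc32)cc1OC`, compound 2 `O=C(COc1nc2ccccc2nc1/C=C\c1ccncc1)Nc1ccc(Cl)cc1` and compound 3 `Cc1ccc(C(=O)Nc2ccc(Cn3c(=O)c(C)nc4ccccc43)cc2)cc1`. None of them yields a number. Compound 1 reaches only the limit of the assay, > 100000 nM. Compound 2 likewise stops at the limit, > 100000 nM. Compound 3 also shows nothing but the limit, > 100000 nM. Compound 3 thus stands at the limit of > 100000 nM in this assay, at which 3 of the 3 values shown sit, as do the other two, and no ranking among them is possible.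

The next compound, compound 4 `Cc1nc2ccccc2n(Cc2ccc(NC(=O)c3ccc(Cl)cc3)cc2)c1=O`, differs from compound 3 in a single place: chloro in place of methyl on an aromatic carbon. Going by the values given here, no step between two measured compounds is available, so nothing measured shows how such an exchange moves the read-out. With every measured compound sitting at the limit, the expected step is a step that the limit leaves unreadable from compound 3 to compound 4, none beyond the usual scatter. Compound 4 is therefore estimated at 150000 nM, within a range from 50000 nM to 500000 nM, most likely reported once more as a limit rather than a number.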

Compound 4, half-maximal inhibitory concentration: > 100000 nM
Compound 4: only a limit was reported; the forecaster's own chance of this, stated with the estimate: 85%; the middle value lies beyond the limit too.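

In this assay, compound 3 and compound 4 each give only a limit, and the exchange of methyl for chloro between them has no readable size. The compounds shown leave open how any of them truly ranks, and which structural change would yield an actual number.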